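Will a larger two-ring group hold the level of compound 3?

A few compounds are considered here, and "the series" means these few. Any claim that something is new, unique, unknown or untested is made for them only; others in the source may bear on it.

Within the data shown here, in a functional assay on DU-145 cells (Homo sapiens) for inhibition, read by trypan blue exclusion, with a stated time of 72 h (on this read-out lower numbers stand for stronger inhibition and higher numbers for weaker inhibition), compound 3 `Cn1c(=O)c(S(=O)(=O)c2ccc(F)cc2F)cc2cnc(Nc3cnc4[nH]ccc4c3)nc21` gives 750 nM and stands level with compound 1 `Cn1c(=O)c(S(=O)(=O)c2ccc(F)cc2F)cc2cnc(Nc3cccc4[nH]ccc34)nc21` at 750 nM as the lowest number so far, while compound 2 `Cn1c(=O)c(S(=O)(=O)c2ccc(F)cc2F)cc2cnc(Nc3ccncn3)nc21` gives 50000 nM by comparison. Compound 4 `Cn1c(=O)c(S(=O)(=O)c2ccc(F)cc2F)cc2cnc(Nc3ccc4c(c3)C(=O)C(=O)N4)nc21` differs from compound 3 by a group of 11 heavy atoms (8 carbon, 1 nitrogen, 2 oxygen; one five-membered non-aromatic ring with 1 hetero atom, one six-membered aromatic ring of carbon only) in place of a group of 9 heavy atoms (7 carbon, 2 nitrogen; one five-membered aromatic ring with 1 hetero atom, one six-membered aromatic ring with 1 hetero atom), on a nitrogen on an aromatic ring and keeps the rest of the molecule. Exchanging one two-ring group for another at this nitrogen gave no change at the digits printed from compound 1 to compound 3 (within the scatter) whereas a single-ring group there gave a 67-fold higher number from compound 1 to compound 2 (1.82 log units; beyond the scatter) and a 67-fold lower number from compound 2 to compound 3 (1.82 log units; beyond the scatter) on the way back. Compound 4 keeps two rings, so the smaller of these steps is the closer guide, although no group like the new one has been measured. In this assay the estimated step is a 2.0-fold higher number from compound 3 to compound 4 (0.30 log units; within the scatter) and it points to a slightly higher number. Compound 4 is estimated at 1500 nM with 300 nM to 8000 nM as the expected range.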

Compound 4, half-maximal inhibitory concentration: 75000 nM
Compound 4: the middle estimate sits 50-fold (1.70 log units) below what was measured; measured number above the stated range.
By their numbers in this assay, from the lowest: compounds 1 and 3 (each within the scatter of the next); then compounds 2 and 4 (each within the scatter of the next).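

Two rings on this nitrogen are not enough to hold the level: in this assay the change gives a 100-fold higher number from compound 3 to compound 4 (2.00 log units; beyond the scatter) and a 100-fold higher number from compound 1 to compound 4 (2.00 log units; beyond the scatter). Compared with the single-ring pyrimidin-4-yl of compound 2, the new two-ring group gives a 1.5-fold higher number from compound 2 to compound 4 (0.18 log units; within the scatter), so ring count alone does not sort these compounds. No supporting measurement accompanies these results to explain the change.

The compounds shown do not separate the effect of the carbonyl groups from that of the rest of the new group. An oxindole, which has one carbonyl in its five-membered ring, would help to make that separation.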